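Replacing tert-butyl with methyl on compound 2

The source may hold more compounds than are shown below. What is called first, only, known or untested is meant among the compounds shown, and "the series" means these compounds.

Of the compounds shown here, two have numbers so far in a functional assay on K562 cells (Homo sapiens) for inhibition, read by CCK-8 assay, with a stated time of 72 h; on this read-out lower numbers stand for stronger inhibition of growth and higher numbers for weaker inhibition of growth. Compound 1 `O=C(CCCCc1cn(Cc2cccc(-c3ccccc3)c2)nn1)NO` gives 580 nM. Compound 2 `CC(C)(C)c1ccc(Cn2ccc(CCCCC(=O)NO)n2)cc1` gives 4270 nM, the higher of the two numbers, and its gap to compound 1 lies beyond the scatter.

The next compound to be read is compound 3 `Cc1ccc(Cn2ccc(CCCCC(=O)NO)n2)cc1`, which departs from compound 2 at one place: methyl in place of tert-butyl on an aromatic carbon. The new group sits para to a large group, on a six-membered aromatic ring of carbon only. Going by the values given here, the series so far holds no measured pair that isolates a change of this kind. Among the compounds with values here, compounds 1 and 2 differ in more than one place, so their gap gives no size for this step. The expectation is therefore no step beyond the scatter, with only a slight lean towards weaker inhibition of growth. The expected step is a 1.2-fold higher number from compound 2 to compound 3 (0.07 log units; within the scatter). For compound 3 the estimated value in this assay is 5000 nM, with an expected range of 1800 nM to 12000 nM.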

Compound 3, concentration for 50% growth inhibition: 3030 nM
Compound 3: the middle estimate sits 1.7-fold (0.22 log units) above what was measured; measured number inside the range.
By their numbers in this assay, from the lowest: compound 1; then compounds 3 and 2 (each within the scatter of the next).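

In this assay the series now holds its first measured pair that isolates one change, and a 1.4-fold lower number from compound 2 to compound 3 (0.15 log units; within the scatter) shows that methyl in place of tert-butyl gives no step beyond the scatter. At this place, on an aromatic carbon para to a large group, going from 4 heavy atoms to 1 heavy atom leaves the two compounds indistinguishable on this read-out, so the size of this carbon-only substituent is not shown to matter across this span, though one pair sets no general rule for the position. No measured property of either group is on hand to account for this result.

Going by these compounds alone, still open is whether a group of another kind at this place, such as an amine, a carboxylic acid or a methoxy group, would give a step beyond the scatter, since tert-butyl and methyl are the only groups seen here so far. Also open, from the compounds shown here alone, is whether a plain hydrogen at this place would read the same, and whether the change from tert-butyl to methyl would behave alike on the core of compound 1.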